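Chloro in place of fluoro on compound 1

A few compounds are considered here, and "the series" means these few. Any claim that something is new, unique, unknown or untested is made for them only; others in the source may bear on it.

Compound 1 `C=C(CC(=O)Nc1ccc(F)cc1F)C(=O)O` is the reference point in an ADME assay on MDCK cells (Canis lupus familiaris) for cytotoxicity, read by MTT assay, with a stated time of 72 h; a higher number here means that more compound is tolerated, a lower number that less compound is tolerated. Compound 1 gives > 110000 nM, which is a limit of the assay and not a number. Compound 2 `C=C(CC(=O)Nc1ccc(Cl)cc1F)C(=O)Nc1ccc(Cl)cc1F` gives > 110000 nM, which is also a limit. Among the compounds with values here, the evidence so far amounts to the limit of > 110000 nM in this assay, at which 2 of the 2 values shown sit, and no measured step between compounds is available to size a change.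

Compound 3 `C=C(CC(=O)Nc1ccc(Cl)cc1F)C(=O)O` has not yet been measured. Compared with compound 1, it has chloro in place of fluoro on an aromatic carbon, meta to a fluoro group: chloro in place of fluoro on an aromatic carbon. The rest of the structure is unchanged.

Compound 2 also carries chloro, and its > 110000 nM is a limit, so no step beyond the scatter is expected in this assay, in either direction. The expected change is a number no higher from compound 1 to compound 3 (the limit leaves the size open), an estimate that stays within the scatter. For compound 3 the estimated value is 110000 nM, with an expected range from 60000 nM to 200000 nM, and the most likely report is again a limit.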

Compound 3, half-maximal cytotoxic concentration: > 110000 nM
Compound 3: a limit, no number; the forecaster's own chance of this, stated with the estimate: 85%; the middle value sits exactly at the limit.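

In this assay compound 3 gives > 110000 nM, a limit and not a number. Within the data shown here, compound 1 also stands at a limit, so no step between compound 1 and compound 3 can be read: the limit of > 110000 nM in this assay, at which 3 of the 3 values shown sit. Where any of these compounds reaches its half-maximal cytotoxic concentration, and whether chloro in place of fluoro shifts it, stays open.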